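Replacing the 4-bromo-3-methylphenyl group of compound 3

A few compounds are considered here, and "the series" means these few. Any claim that something is new, unique, unknown or untested is made for them only; others in the source may bear on it.

In an ADME assay on MT4 cells (Homo sapiens) for cytotoxicity, read by MTT assay (on this read-out lower numbers stand for higher toxicity in this test and higher numbers for lower toxicity in this test), compound 3 `Cc1cc(C(=O)N(C(=S)OCCN2C(=O)c3ccccc3C2=O)c2ccc(Cl)cc2)ccc1Br` gives 18000 nM, the lowest of the three numbers, against compound 1 `O=C1c2ccccc2C(=O)N1CCOC(=S)N(C(=O)c1ccc(F)cc1F)c1ccc(Cl)cc1` at 52000 nM and compound 2 `O=C1c2ccccc2C(=O)N1CCOC(=S)N(C(=O)c1cc(F)cc(F)c1)c1ccc(Cl)cc1` at 59000 nM. Compound 4 `Cc1cc(C(=O)N(C(=S)OCCN2C(=O)c3ccccc3C2=O)c2ccc(Cl)cc2)c(C)o1` carries 2,5-dimethylfuran-3-yl in place of 4-bromo-3-methylphenyl on a carbonyl carbon. The measured steps at this same place are a 2.9-fold lower number from compound 1 to compound 3 (0.46 log units; beyond the scatter) and a 3.3-fold lower number from compound 2 to compound 3 (0.52 log units; beyond the scatter), both modest, while a 1.1-fold higher number from compound 1 to compound 2 (0.05 log units; within the scatter) stays within the scatter. Among the measured compounds shown here, no measured compound carries the 2,5-dimethylfuran-3-yl group, so the expectation is loose. A modest step towards a higher number is expected, estimated as a 2.1-fold higher number from compound 3 to compound 4 (0.32 log units; beyond the scatter). For compound 4 the estimated value is 38000 nM, with an expected range from 15000 nM to 80000 nM.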

Compound 4, half-maximal cytotoxic concentration: 40000 nM
The estimate for compound 4 lay 1.1-fold (0.02 log units) below the measured number; the range from low to high includes it.
By their numbers in this assay, from the lowest: compound 3; then compounds 4, 1 and 2 (each within the scatter of the next).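

In this assay, 2,5-dimethylfuran-3-yl on the carbonyl carbon reverses the drop seen with 4-bromo-3-methylphenyl, giving a 2.2-fold higher number from compound 3 to compound 4 (0.35 log units; beyond the scatter). Against the two difluorophenyl compounds, the furan shows a 1.5-fold lower number from compound 2 to compound 4 (0.17 log units; within the scatter) and a 1.3-fold lower number from compound 1 to compound 4 (0.11 log units; within the scatter), both within the scatter, so this position accepts a five-membered aromatic ring with 1 hetero atom and compound 3 alone stands apart. Nothing available explains this shift. From the compounds shown here alone, it remains open whether the bromine or the methyl of compound 3 accounts for its lower number, and how an amine or a carboxylic acid would read at this place.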